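The source may report more compounds than this note shows. Statements on the series, on what has been measured and on what is new or still open speak of the compounds shown alone.

Measured in a physicochemical assay for lipophilicity, at pH 7.4; a lower number here means a more polar compound, a higher number a more lipophilic compound:
- compound 1 `CCc1ccc(N(CC2CCC2)S(=O)(=O)c2ccc3c(c2)C(=O)CC(C2CCOCC2)O3)cc1`: 4.1
- compound 2 `CC(C)CN(c1ccc(C#N)cc1)S(=O)(=O)c1ccc2c(c1)C(=O)CC(C1CCOCC1)O2`: 3.16
- compound 3 `CCc1ccc(NS(=O)(=O)c2ccc3c(c2)C(=O)CC(C2CCOCC2)O3)cc1`: 2.67

Compound 2, at 3.16, stands second highest of the three, with both other values beyond the scatter from it. Compound 4 `CC(C)CN(c1ccccc1F)S(=O)(=O)c1ccc2c(c1)C(=O)CC(C1CCOCC1)O2` has 2-fluorophenyl in place of 4-cyanophenyl on a sulfonamide nitrogen. Going by the values given here, the only measured step, a number 1.43 log units lower from compound 1 to compound 3 (beyond the scatter), is large, but it exchanges cyclobutylmethyl for hydrogen and so bears only loosely on this change. Among the compounds with values here, no measured step isolates the new exchange, so the expectation is a judgement and a moderate rise in this assay is foreseen. The expected step is a number 0.44 log units higher from compound 2 to compound 4 (beyond the scatter). For compound 4 the estimated value is 3.6, with an expected range from 3.2 to 4.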

Compound 4, distribution coefficient: 3.44
Compound 4: middle estimate off by 0.16 log units, on the high side, and the stated range covers the measured number.
By their numbers in this assay, from the lowest: compound 3; then compounds 2 and 4 (each within the scatter of the next); then compound 1.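

In this assay the exchange of 4-cyanophenyl for 2-fluorophenyl on this sulfonamide nitrogen gives a number 0.28 log units higher from compound 2 to compound 4 (within the scatter) and so leaves the read-out where it was. This is the first step among these compounds that exchanges one substituted phenyl for another at this position, and the two groups cannot be told apart here. Nothing measured here offers an explanation for this result.

On these data alone, whether 4-fluorophenyl would read like 2-fluorophenyl remains open. So does whether a phenyl bearing an amine or a carboxylic acid on this nitrogen would shift the number beyond the scatter.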